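Amide substituent changes on the shared core

The source may report more compounds than this note shows. Statements on the series, on what has been measured and on what is new or still open speak of the compounds shown alone.

Within the data shown here, compound 1 `CC1(C)Cc2c(sc(NC(=O)c3ccccc3O)c2C(N)=O)C(C)(C)O1` gives 162 nM in an assay on cells for positive allosteric modulation of Cystic fibrosis transmembrane conductance regulator variant G551D (Homo sapiens), with stated times of 10 min and 2 min, in the presence of a further agent that is not named here (on this read-out lower numbers stand for an effect already at smaller amounts and higher numbers for an effect only at larger amounts of compound), the lowest of the three numbers measured so far. Compound 2 `CC1(C)Cc2c(sc(NC(=O)c3ccn[nH]3)c2C(N)=O)C(C)(C)O1` gives 339 nM and compound 3 `CC1(C)Cc2c(sc(NC(=O)[C@H](O)C(C)(C)C)c2C(N)=O)C(C)(C)O1` gives 7780 nM. The step of a 2.1-fold higher number from compound 1 to compound 2 (0.32 log units; beyond the scatter) is modest, whereas a 48-fold higher number from compound 1 to compound 3 (1.68 log units; beyond the scatter) and a 23-fold higher number from compound 2 to compound 3 (1.36 log units; beyond the scatter) are large. Compound 4 `Cc1cc(C(=O)Nc2sc3c(c2C(N)=O)CC(C)(C)OC3(C)C)[nH]n1` differs from compound 1 in one place: 3-methyl-1H-pyrazol-5-yl in place of 2-hydroxyphenyl on a carbonyl carbon. Among the measured compounds shown here, the step of a 2.1-fold higher number from compound 1 to compound 2 (0.32 log units; beyond the scatter) bears most directly on this change, as it too brings a five-membered aromatic ring with two hetero atoms onto the carbonyl carbon; no measured step shows what the added methyl does. A modest rise in number is therefore expected, a 2.5-fold higher number from compound 1 to compound 4 (0.39 log units; beyond the scatter). For compound 4 the estimate is 400 nM, with a range from 150 nM to 1100 nM.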

Compound 4, half-maximal effective concentration: 590 nM
Compound 4: middle estimate off by 1.5-fold (0.17 log units), on the low side; measured number inside the range.
By their numbers in this assay, from the lowest: compound 1; then compounds 2 and 4 (each within the scatter of the next); then compound 3.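

Methyl in place of hydrogen on an aromatic carbon gives a 1.7-fold higher number from compound 2 to compound 4 (0.24 log units; within the scatter), so in this assay the added methyl cannot be told apart from hydrogen. The 3-methyl-1H-pyrazol-5-yl group stays behind 2-hydroxyphenyl on the carbonyl carbon, with a 3.6-fold higher number from compound 1 to compound 4 (0.56 log units; beyond the scatter), but well ahead of 1-hydroxy-2,2-dimethylpropyl, with a 13-fold lower number from compound 3 to compound 4 (1.12 log units; beyond the scatter). Still open, going by these compounds, is whether an ethyl or longer chain in place of the methyl, or an aminomethyl group there, would move the number beyond the scatter. No evidence on the cause of these steps is at hand.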